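The source may hold more compounds than are shown below. What is called first, only, known or untested is meant among the compounds shown, and "the series" means these compounds.

Compound 2 `O=C(CO[N+](=O)[O-])Nc1ccc(C(=O)/C=C/c2ccc(Cl)cc2)cc1` gives 57% in a functional assay on the whole organism (strain albino) for inhibition, with Rattus norvegicus as the target, read by paw edema, with stated times of 30 min and 2 h, at a dose of 100 mg/kg by the oral route (a higher number here means more inhibition at the dose given (going by the name of the read-out), a lower number less inhibition), standing highest of the two numbers shown, though its nearest neighbour, compound 1 `Nc1ccc(C(=O)/C=C/c2ccc(Cl)cc2)cc1`, gives 50% and the step of a number 7 percentage points higher from compound 1 to compound 2 (within the scatter) lies within the scatter. Compound 3 `CC(Br)C(=O)Nc1ccc(C(=O)/C=C/c2ccc(Cl)cc2)cc1` has not yet been measured; it differs from compound 2 by 1-bromoethyl in place of (nitrooxy)methyl on a carbonyl carbon. Going by the values given here, the only measured step that bears on this change is the one putting ((nitrooxy)methyl)carbonyl in place of hydrogen on a nitrogen on an aromatic ring, which stayed within the scatter, so the change to compound 3 is expected to give a step of a number 3 percentage points lower from compound 2 to compound 3 (within the scatter) in this assay, nothing beyond the scatter. Compound 3 is therefore estimated at 54%, ranging from 40% to 68%.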

Compound 3, a percentage reported as inhibition, in the whole organism at one dose (the size of the read-out at that dose, not a potency): 45%
For compound 3 the middle estimate is 9 percentage points above the measured one, within the range that was stated.
By their numbers in this assay, from the lowest: compounds 3, 1 and 2 (each within the scatter of the next, the first and the last beyond it).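

Placed on the carbonyl carbon, 1-bromoethyl and (nitrooxy)methyl can be told apart in this assay, where the change gives a number 12 percentage points lower from compound 2 to compound 3 (beyond the scatter), the first step shown here to pass beyond the scatter. Against hydrogen on the nitrogen, the same acyl group gives only a number 5 percentage points lower from compound 1 to compound 3 (within the scatter), so only the two acyl groups are separated from each other, and neither is separated from hydrogen. Nothing available explains this difference.

The compounds shown leave open how a plain ethyl group, without bromine, would stand on this carbonyl carbon. Also open, on these data alone, is how a longer chain carrying the nitrooxy group would stand there in this assay.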